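A few compounds are considered here, and "the series" means these few. Any claim that something is new, unique, unknown or untested is made for them only; others in the source may bear on it.

Measured so far:
compound 1, `Cc1ccc(S(=O)(=O)N2C=CNC(=O)[C@H]2CC(=O)N[C@H]2CCN(C)CC2(C)C)cc1` — 0.42 nM
compound 2, `Cc1cc(S(=O)(=O)N2C=CNC(=O)[C@H]2CC(=O)N[C@H]2CCN(C)CC2(C)C)c(C)cc1Cl` — 0.28 nM

Both numbers come from an in vitro functional assay on cells for antagonist activity at B1 bradykinin receptor (Homo sapiens), read by luminescence and calcium flux, with a stated time of 2 h; on this read-out lower numbers stand for stronger inhibition and higher numbers for weaker inhibition. Compound 2 gives the lowest of the two numbers, but its step from compound 1, a 1.5-fold lower number from compound 1 to compound 2 (0.18 log units; within the scatter), lies within the scatter, so no order between them is claimed.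

Compound 3, `CN1CC[C@H](NC(=O)C[C@@H]2C(=O)NC=CN2S(=O)(=O)c2cccc(Cl)c2Cl)C(C)(C)C1`, carries a change at the same position: 2,3-dichlorophenyl in place of 4-chloro-2,5-dimethylphenyl on a sulfonyl sulfur. Going by the values given here, the only step touching that position, a 1.5-fold lower number from compound 1 to compound 2 (0.18 log units; within the scatter), was within the scatter, so a step of similar size is expected here, with no preferred direction.

For compound 3 in this assay the expected value is 0.45 nM, between 0.15 nM and 1.5 nM, an expected step of a 1.6-fold higher number from compound 2 to compound 3 (0.21 log units; within the scatter).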

Compound 3, half-maximal inhibitory concentration: 0.22 nM
For compound 3 the middle estimate is 2.0-fold (0.31 log units) above the measured one, within the range that was stated.
By their numbers in this assay, from the lowest: compounds 3, 2 and 1 (each within the scatter of the next).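

Replacing 4-chloro-2,5-dimethylphenyl with 2,3-dichlorophenyl on the sulfonyl sulfur gives a 1.3-fold lower number from compound 2 to compound 3 (0.10 log units; within the scatter) in this assay, while replacing 4-methylphenyl with it gives a 1.9-fold lower number from compound 1 to compound 3 (0.28 log units; within the scatter) at the same place. Compound 3 thus adds a phenyl group with chlorine and no methyl, and all three groups remain within the scatter of one another. No measurement bearing on a cause for this is available.

All three compounds carry a substituted phenyl on the sulfonyl sulfur. Going by these compounds, whether a phenyl bearing an amine or a carboxylic acid, or a pyridine ring, would stay in this range remains open.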